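Shortening the acid chain: what the exposure data suggest

The source may report more compounds than this note shows. Statements on the series, on what has been measured and on what is new or still open speak of the compounds shown alone.

Measured so far:
Compound 1, `CN(Cc1ccccc1OCCCCCC(=O)O)C(=O)c1ccc(-c2ccco2)cc1`: 1100 ng.h/mL
Compound 2, `CN(Cc1ccccc1OCCCCC(C)(C)C(=O)O)C(=O)c1ccc(-c2ccco2)cc1`: 48400 ng.h/mL

In an ADME assay on the whole organism (strain CD-1) for pharmacokinetics, with Mus musculus as the target, at a dose of 3 mg/kg by the intravenous route (a lower number here means less compound in the circulation, a higher number more compound in the circulation at the dose given), compound 1 gives 1100 ng.h/mL, and compound 2 gives 48400 ng.h/mL. Going by the values given here, the single step between them, a 44-fold higher number from compound 1 to compound 2 (1.64 log units; beyond the scatter), places compound 2 at the top of the two numbers so far, with compound 1 the only neighbour and far below it.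

Compound 3, `CN(Cc1ccccc1OCCC/C=C/C(=O)O)C(=O)c1ccc(-c2ccco2)cc1`, has not yet been measured. Compared with compound 2 the change is 2-carboxyethenyl in place of 2-carboxy-2-methylpropyl on a saturated chain carbon, three bonds along the chain from an oxygen on an aromatic ring. The group that enters carries the acid on a shorter, unsaturated arm with no branching, so compound 3 resembles compound 1 in having no methyl groups on the carbon that bears the acid, while being shorter than either measured compound.

Among the compounds with values here, only one step bears on this: the large gain in a 44-fold higher number from compound 1 to compound 2 (1.64 log units; beyond the scatter), which accompanied the introduction of that branching. Removing it again is expected to undo much of that gain, so a large drop, a 19-fold lower number from compound 2 to compound 3 (1.29 log units; beyond the scatter), is expected. Compound 3 is therefore estimated at 2500 ng.h/mL, with a range from 600 ng.h/mL to 12000 ng.h/mL.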

Compound 3, area under the concentration-time curve: 750 ng.h/mL
The estimate for compound 3 lay 3.3-fold (0.52 log units) above the measured number; the range from low to high includes it.
By their numbers in this assay, from the lowest: compounds 3 and 1 (each within the scatter of the next); then compound 2.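

The new result separates two changes that compound 2 and compound 3 combine: in this assay, a 65-fold lower number from compound 2 to compound 3 (1.81 log units; beyond the scatter) shows that replacing 2-carboxy-2-methylpropyl with 2-carboxyethenyl loses the high number seen for compound 2. The comparison with the unbranched saturated chain is more specific. Here a 1.5-fold lower number from compound 1 to compound 3 (0.17 log units; within the scatter) shows that 2-carboxyethenyl in place of 2-carboxyethyl, which adds a double bond to the chain, makes no difference that can be told from scatter. Among these compounds, then, only the one carrying 2-carboxy-2-methylpropyl stands apart, and no measurement here explains the difference in circulating compound.

Still open, going by these compounds, is whether both methyl groups are needed, which a 2-carboxypropyl group carrying a lone methyl would test, and whether a double bond would matter in a chain that keeps its methyl groups. It is also unknown whether the high number depends on the carboxylic acid itself, a question that a tetrazole or a primary amide in its place would address.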